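The source may report more compounds than this note shows. Statements on the series, on what has been measured and on what is new or still open speak of the compounds shown alone.

Measured compounds in a functional assay on PC-3 cells (Homo sapiens) for antiproliferative activity, read by MTT assay, with a stated time of 48 h; a lower number here means a stronger inhibitor of growth, a higher number a weaker inhibitor of growth:
compound 1 `Cc1ccc(OCCCN(Cc2ccc(C(=O)NO)cc2)c2ncc(-c3ccc(C)cc3)s2)cc1` gives 9330 nM
compound 2 `CCCN(Cc1ccc(C(=O)NO)cc1)c1ncc(-c2ccc(C)cc2)s1` gives 9160 nM
compound 3 `Cc1ccc(-c2cnc(N(CCCOc3ccccc3)Cc3ccc(C(=O)NO)cc3)s2)cc1` gives 17500 nM

Compound 3 holds the largest number of the three, but this is not a separation: a 1.9-fold higher number from compound 1 to compound 3 (0.27 log units; within the scatter) and a 1.9-fold higher number from compound 2 to compound 3 (0.28 log units; within the scatter) both sit within the scatter, so the three measured compounds stand at one level.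

The next compound is compound 4 `CCN(Cc1ccc(C(=O)NO)cc1)c1ncc(-c2ccc(C)cc2)s1`, differing from compound 3 by hydrogen in place of phenoxymethyl on a saturated chain carbon, two bonds along the chain from a nitrogen on an aromatic ring. Among the measured compounds shown here, two measured steps bear on this. The step of a 1.9-fold higher number from compound 2 to compound 3 (0.28 log units; within the scatter) is the near-reverse of the present change, cut one bond further out, and it stayed within the scatter. The step of a 1.0-fold lower number from compound 1 to compound 2 (0.01 log units; within the scatter), which also strips an aryloxy-bearing chain down to a short alkyl on the same nitrogen, was flat as well. Nothing in the measured set suggests that shortening the chain on that nitrogen moves the number beyond the scatter in either direction, and the shorter chain of compound 4 sits between what has been seen.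

For compound 4 the expected step of a 1.8-fold lower number from compound 3 to compound 4 (0.24 log units; within the scatter) is therefore no change beyond the scatter, with the estimate for compound 4 at 10000 nM and a range from 5000 nM to 20000 nM.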

Compound 4, concentration for 50% growth inhibition: 10300 nM
Beside the measured number, compound 4's estimate is 1.0-fold (0.01 log units) below it, within the range that was stated.
By their numbers in this assay, from the lowest: compounds 2, 1, 4 and 3 (each within the scatter of the next).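

In this assay, the whole phenoxymethyl group can be replaced by hydrogen at this place, on a saturated chain carbon two bonds along the chain from a nitrogen on an aromatic ring, with the change staying within the scatter: a 1.7-fold lower number from compound 3 to compound 4 (0.23 log units; within the scatter). The ethyl chain of compound 4 also stands level with the propyl chain of compound 2, a 1.1-fold higher number from compound 2 to compound 4 (0.05 log units; within the scatter), and with the longer methylphenoxy-ended chain of compound 1, a 1.1-fold higher number from compound 1 to compound 4 (0.04 log units; within the scatter), so all four compounds sit at one level across these chains on that nitrogen. No evidence on hand speaks to why this change leaves the number flat.

Open, going by these compounds, is whether an amine or a carboxylic acid at the end of this chain would move the number beyond the scatter. On these data alone, a plain methyl on that nitrogen, or a much longer alkyl chain, also remains open.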